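From ethoxy to octyloxy, starting at an assay limit

The compounds below may be only part of what the source reports. "The series", "measured", "known", "first", "only" and "open" are said of these compounds alone.

Compound 1 `Nc1nc(OCC(F)(F)F)c2ncn(/C=C3/CC3(CO)CO)c2n1`: > 20000 nM
Compound 2 `CCOc1nc(N)nc2c1ncn2/C=C1/CC1(CO)CO`: > 20000 nM

The test here is an ADME assay on BCBL1 cells (Homo sapiens) for cytotoxicity, with a stated time of 7 days; on this read-out lower numbers stand for higher toxicity in this test and higher numbers for lower toxicity in this test. Compound 2 gives only a limit of this assay, > 20000 nM, not a number. Compound 1 likewise gives only a limit, > 20000 nM. The evidence so far is thus (the limit of > 20000 nM in this assay, at which 2 of the 2 values shown sit).

Compound 3 `CCCCCCCCOc1nc(N)nc2c1ncn2/C=C1/CC1(CO)CO` turns ethoxy into octyloxy: hexyl in place of hydrogen on a saturated chain carbon, two bonds along the chain from an oxygen on an aromatic ring. Among the compounds with values here, the one measured step, a step that the two limits leave unreadable from compound 1 to compound 2, has no readable size, so it offers no guide to the size of this change. Within the data shown here, no measured compound carries a chain of this length. A small move towards higher toxicity is allowed for, but another result at the limit is about equally likely. The expected step is an at least 1.3-fold lower number from compound 2 to compound 3 (0.12 log units; that floor lies within the scatter), and its direction is only tentative. Compound 3 is expected at 15000 nM, with an estimated range from 4000 nM to 40000 nM.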

Compound 3, half-maximal cytotoxic concentration: > 20000 nM
Compound 3 ended at the assay's limit; the forecaster's own chance of this, stated with the estimate: 50%; middle value at least 1.3-fold (0.12 log units) away from the limit.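

Compound 3 gives only a limit in this assay, as do compound 1 and compound 2, so no step among these three compounds can be read. Whether going from ethoxy to octyloxy changes toxicity in this test stays open, because all three share one limit: the limit of > 20000 nM in this assay, at which 3 of the 3 values shown sit.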